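Trifluorophenyl for methoxyphenyl: where solubility may land

The source may report more compounds than this note shows. Statements on the series, on what has been measured and on what is new or still open speak of the compounds shown alone.

Among the compounds with values here, compound 3 `COc1ccc(-c2cnn3c(NCc4ccccn4)cc(C)nc23)cc1` is one of three compounds measured in a physicochemical assay for solubility, read by HPLC, using the shake flask method, measured as kinetic solubility, with a stated time of 2 h, at pH 7.4; on this read-out higher numbers stand for higher solubility and lower numbers for lower solubility. In this assay compound 3 gives < 5000 nM, which is a limit of the assay and not a number. Its closest measured neighbour, compound 2 `COc1ccc(-c2c(C)nn3c(NCc4ccccn4)cc(C)nc23)cc1`, differs only by hydrogen in place of methyl on an aromatic carbon. In this assay compound 2 gives < 5000 nM, again a limit of the assay. The step that the two limits leave unreadable from compound 2 to compound 3 therefore cannot be read. Within the data shown here, compound 1 `Cc1cc(NCCCc2ccccn2)n2nc(C)c(-c3ccccc3)c2n1`, the third measured compound, gives 5900 nM in this assay, the only true number among the three. Compound 4 `Cc1cc(NCc2ccccn2)n2ncc(-c3cc(F)c(F)c(F)c3)c2n1`, not yet measured, differs from compound 3 by 3,4,5-trifluorophenyl in place of 4-methoxyphenyl on an aromatic carbon. Among the measured compounds shown here, no measured step involves this change, so neither direction nor size can be drawn from the data; the only guidance is the limit of < 5000 nM in this assay, at which 2 of the 3 values shown sit. Compound 4 is therefore expected to stay near that same limit, an expected step that the limit leaves unreadable from compound 3 to compound 4. The estimate for compound 4 is 2500 nM, within 500 nM to 6000 nM.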

Compound 4, solubility: < 5000 nM
Compound 4: only a limit was reported; the forecaster's own chance of this, stated with the estimate: 75%; the middle value does not contradict the limit.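

In this assay, within the data shown here, compound 3 and compound 4 each give only a limit of the assay and not a number, so no step between them can be read. The compounds shown leave open what solubility either compound truly has, and whether 3,4,5-trifluorophenyl in place of 4-methoxyphenyl shifts it in either direction.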